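Replacing 2-methylpyridin-4-yl with 3-fluoropyridin-4-yl

The compounds below may be only part of what the source reports. "The series", "measured", "known", "first", "only" and "open" are said of these compounds alone.

Of the compounds shown here, two have been measured so far in a physicochemical assay for lipophilicity, using the shake flask method, in phosphate buffer, measured as octanol-water partition, at pH 7.4 (on this read-out higher numbers stand for higher lipophilicity and lower numbers for lower lipophilicity), as the read-out. Compound 1 (`C[C@@H]1CN(C(=O)OC(C)(C)C)CCN1c1ncc(OCc2ccc(-n3cnnn3)cc2)cn1`) gives > 4.3 as a limit, not as a number. Compound 2 (`Cc1cc(COc2cnc(N3CCN(C(=O)OC(C)(C)C)CC3)nc2)ccn1`) gives 3.7 as an exact number, the only one available to build on.

Compound 3 (`CC(C)(C)OC(=O)N1CCN(c2ncc(OCc3ccncc3F)cn2)CC1`) has not yet been measured. It differs from compound 2 in one place (3-fluoropyridin-4-yl in place of 2-methylpyridin-4-yl on a saturated chain carbon bound to an oxygen on an aromatic ring): 3-fluoropyridin-4-yl stands in place of 2-methylpyridin-4-yl on a saturated chain carbon bound to an oxygen on an aromatic ring. The rest of the structure stays the same.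

Among the measured compounds shown here, no measured pair of compounds shows what this kind of swap does, so any forecast here is tentative. The two groups match in what is counted for them, and only a small shift is expected. Starting from compound 2 at 3.7 as the anchor, the estimated step of a number 0.20 log units lower from compound 2 to compound 3 (within the scatter) is slightly downward and is not expected to go beyond the usual scatter of repeated measurements. Compound 3 is expected to read 3.5 in this assay (estimated range 3.1 to 3.9).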

Compound 3, distribution coefficient: 3.6
Beside the measured number, compound 3's estimate is 0.10 log units below it; low and high end bracket the measured number.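

Among the compounds shown here, this is the first measured pair that isolates a swap at this position, and in this assay it gives a number 0.10 log units lower from compound 2 to compound 3 (within the scatter). The swap puts 3-fluoropyridin-4-yl in place of 2-methylpyridin-4-yl on a saturated chain carbon bound to an oxygen on an aromatic ring, and both groups have the same counts of heavy atoms, hydrogen-bond donors and hydrogen-bond acceptors. For this one pair, then, exchanging these two groups leaves the read-out within the scatter, but nothing measured here explains why the two compounds read so alike.

Because the methyl group leaves as the fluorine enters, this single pair cannot separate what each contributes, and it says nothing about how a plain pyridin-4-yl, or a ring carrying an amine or a carboxylic acid, would read at the same place. For the compounds shown here, compound 1 gives > 4.3, which is a limit of the assay and not a number, and it differs from the other compounds in more than one place, so it offers no step to read.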